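Working notes: methyl in place of bromo

This account rests on a few compounds, and the source may have more. Where it says the series, first, only, none or still open, it means among the compounds named here.

compound 1 `CC1(C)[C@H]2CC[C@]1(C)N(Cc1cn(-c3cccc(C#N)c3)nn1)C(=O)C2` gives 320 nM
compound 2 `CC1(C)[C@H]2CC[C@]1(C)N(Cc1cn(-c3ccc(Br)cc3)nn1)C(=O)C2` gives 60 nM

In a functional assay on LoVo cells (Homo sapiens) for inhibition, read by MTT assay, with a stated time of 24 h (on this read-out higher numbers stand for weaker inhibition and lower numbers for stronger inhibition), compound 2 holds the lower of the two numbers. Compound 3 `Cc1ccc(-n2cc(CN3C(=O)C[C@@H]4CC[C@@]3(C)C4(C)C)nn2)cc1` differs from it by methyl in place of bromo on an aromatic carbon in one place, methyl in place of bromo on an aromatic carbon, para to a large group. Among the compounds with values here, the only measured step is a 5.3-fold lower number from compound 1 to compound 2 (0.73 log units; beyond the scatter) and it exchanges other groups, so it serves only as a rough scale. Within the data shown here, no measured compound carries methyl. Expected in this assay is a modest step to a higher number, estimated as a 2.2-fold higher number from compound 2 to compound 3 (0.34 log units; beyond the scatter) for now. Compound 3 is estimated at 130 nM within a range of 45 nM to 380 nM on this read-out.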

Compound 3, half-maximal inhibitory concentration: 50 nM
Compound 3: middle estimate off by 2.6-fold (0.41 log units), on the high side, and the stated range covers the measured number.
By their numbers in this assay, from the lowest: compounds 3 and 2 (each within the scatter of the next); then compound 1.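

In this assay, bromo and methyl on this aromatic carbon, para to a large group, cannot be told apart, with a 1.2-fold lower number from compound 2 to compound 3 (0.08 log units; within the scatter). The 4-methylphenyl group stays clear of 3-cyanophenyl, with a 6.4-fold lower number from compound 1 to compound 3 (0.81 log units; beyond the scatter), so the gain seen with 4-bromophenyl does not depend on bromine itself. No evidence at hand bears on what underlies this match between the two groups. Open, from the compounds shown here alone, is whether an amine, a carboxylic acid or a longer chain at this same position would keep the number, and whether an unsubstituted phenyl would do so.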